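The source may report more compounds than this note shows. Statements on the series, on what has been measured and on what is new or still open speak of the compounds shown alone.

Working notes on the series in a functional assay on HeLa cells (Homo sapiens) for cytotoxicity, read by MTT assay, with a stated time of 24 h; on this read-out higher numbers stand for weaker inhibition and lower numbers for stronger inhibition. Compound 1 `C=CC1=C(C(=O)Nc2cccc(C)c2)C(c2ccc(F)cc2)OC1` gives "not active" (no number reported) in this assay, so no single number stands for it. Compound 2 `C=CC1=C(C(=O)NCc2ccc(C)cc2)C(c2ccc(F)cc2)OC1` gives > 100000 nM in this assay, which is a limit of the assay and not a number. The data also give (the limit of > 100000 nM in this assay, at which 1 of the 2 values shown sits). Going by the values given here, compound 1 therefore stands without a number of its own, and the one further value shown beside it is a limit rather than a measurement. The move from compound 1 to compound 3 `C=CC1=C(C(=O)O)C(c2ccc(F)cc2)OC1` is hydroxy in place of (3-methylphenyl)amino on a carbonyl carbon. Among the compounds with values here, no step between two measured compounds is available, so no measured change can be carried over to this move. Both measured compounds show nothing within the readable range of this assay, and the change from compound 1 to compound 3 gives no ground to expect a shift beyond the scatter in either direction. The working expectation is that compound 3 also stays without a readable number. Compound 3 is expected to give about 100000 nM in this assay, with a range from 30000 nM to 300000 nM.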

Compound 3, half-maximal inhibitory concentration: 67400 nM
The estimate for compound 3 lay 1.5-fold (0.17 log units) above the measured number; the measured number falls inside the stated range.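

In this assay compound 3 gives 67400 nM, while compound 1 gives "not active" (no number reported), so no new step can be read from this pair. The compounds shown leave open how far hydroxy in place of (3-methylphenyl)amino on the carbonyl carbon shifts this read-out.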